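Amide to urea exchange on a sulfonate ester series

The source may hold more compounds than are shown below. What is called first, only, known or untested is meant among the compounds shown, and "the series" means these compounds.

Of the compounds shown here, three on the shared core have been measured in a functional assay on HT-29 cells (Homo sapiens) for antiproliferative activity, read by sulforhodamine B assay, with a stated time of 48 h; a lower number here means a stronger inhibitor, a higher number a weaker inhibitor. Compound 1 `CC(C)c1ccccc1OS(=O)(=O)c1cccc(NC(=O)CCCl)c1` gives 11000 nM. Compound 2 `CC(C)C(=O)Nc1ccc(S(=O)(=O)Oc2ccccc2I)cc1` gives 13000 nM, the highest of the three numbers; its gap to compound 1 lies within the scatter, so these two are not told apart. Compound 3 `CC(C)c1ccccc1OS(=O)(=O)c1ccc(NC(=O)CCCCl)cc1` gives 6200 nM, a lower number than that of compound 2 by a margin beyond the scatter. Going by the values given here, no pair among the three differs in one place only, so no single structural step has yet been measured.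

Compound 4 `CCNC(=O)Nc1ccc(S(=O)(=O)Oc2ccccc2I)cc1` is not yet measured. It differs from compound 2 by ethylamino in place of isopropyl on a carbonyl carbon, so the (isopropylcarbonyl)amino group becomes an (ethylcarbamoyl)amino group. Among the compounds with values here, nothing among the measured compounds isolates this exchange, so the expectation rests on compound 2 alone. In this assay compound 4 is expected to give 12000 nM, within 4000 nM to 36000 nM. The estimated step of a 1.1-fold lower number from compound 2 to compound 4 (0.03 log units; within the scatter) amounts to no shift beyond the scatter in either direction.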

Compound 4, half-maximal inhibitory concentration: 5300 nM
Beside the measured number, compound 4's estimate is 2.3-fold (0.35 log units) above it; the range from low to high includes it.
By their numbers in this assay, from the lowest: compounds 4, 3, 1 and 2 (each within the scatter of the next, the first and the last beyond it).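

In this assay, ethylamino in place of isopropyl on a carbonyl carbon gives a 2.5-fold lower number from compound 2 to compound 4 (0.39 log units; beyond the scatter), the first single-place step read in this series. The group on this carbonyl carbon therefore does affect the read-out, and the (ethylcarbamoyl)amino group gives a stronger inhibitor than the (isopropylcarbonyl)amino group; the change also adds a hydrogen-bond donor, but this single step cannot show whether that addition matters. No evidence on the origin of this step is available.

From the compounds shown here alone, an isopropylamino or a dimethylamino group on the same carbonyl carbon would help separate the contribution of the nitrogen from that of the chain, and both remain open. Going by these compounds, whether the same exchange gives a similar step on the core of compound 3 is also open.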